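The source may hold more compounds than are shown below. What is called first, only, known or untested is meant among the compounds shown, and "the series" means these compounds.

Of the compounds shown here, three that share one core have been tested so far. Compound 1 `Cc1cc(O)c(C2=NN(c3ccc(S(N)(=O)=O)cc3)C(c3ccccc3O)C2)cc1Cl` carries a 2-hydroxyphenyl group on a saturated ring carbon; in a functional assay on OVCAR-5 cells (Homo sapiens) for antiproliferative activity, with a stated time of 48 h (on this read-out higher numbers stand for weaker inhibition of growth and lower numbers for stronger inhibition of growth), compound 1 gives 3750 nM. Compound 2 `Cc1cc(O)c(C2=NN(c3ccc(S(N)(=O)=O)cc3)C(c3ccccc3Cl)C2)cc1Cl` has a chloro in place of that hydroxy, and in this assay compound 2 gives 3300 nM; the step of a 1.1-fold lower number from compound 1 to compound 2 (0.06 log units; within the scatter) lies within the scatter, so these two cannot be told apart. Compound 3 `Cc1cc(O)c(C2=NN(c3ccc(S(N)(=O)=O)cc3)C(/C=C/c3ccccc3)C2)cc1Cl` carries a 2-phenylethenyl group on the same saturated ring carbon, and in this assay compound 3 gives 14700 nM. That is the highest of the three numbers, so compound 3 is the weakest inhibitor of growth in the set, as shown by the steps of a 3.9-fold higher number from compound 1 to compound 3 (0.59 log units; beyond the scatter) and a 4.5-fold higher number from compound 2 to compound 3 (0.65 log units; beyond the scatter).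

Compound 4 `COc1ccc(C2CC(c3cc(Cl)c(C)cc3O)=NN2c2ccc(S(N)(=O)=O)cc2)cc1OC` differs from compound 3 in one place: 3,4-dimethoxyphenyl in place of 2-phenylethenyl on a saturated ring carbon. The two measured steps that bear on this change are those from an aromatic ring to the 2-phenylethenyl group, and each raised the number by a modest amount. Returning to an aromatic ring is therefore expected to lower the number by a comparable modest step, a 3.3-fold lower number from compound 3 to compound 4 (0.51 log units; beyond the scatter). Compound 4 is estimated to give about 4500 nM, with a range from 1500 nM to 14000 nM.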

Compound 4, concentration for total growth inhibition: 6360 nM
Beside the measured number, compound 4's estimate is 1.4-fold (0.15 log units) below it; low and high end bracket the measured number.
By their numbers in this assay, from the lowest: compounds 2, 1 and 4 (each within the scatter of the next); then compound 3.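

In this assay, the step of a 2.3-fold lower number from compound 3 to compound 4 (0.36 log units; beyond the scatter) shows that a third aromatic ring on this saturated ring carbon, now one carrying two methoxy groups, also inhibits growth more strongly than 2-phenylethenyl, which leaves compound 3 as the weakest inhibitor of the four. The steps of a 1.9-fold higher number from compound 2 to compound 4 (0.28 log units; within the scatter) and a 1.7-fold higher number from compound 1 to compound 4 (0.23 log units; within the scatter) both lie within the scatter, so 3,4-dimethoxyphenyl cannot be told apart from 2-chlorophenyl or 2-hydroxyphenyl, and this position accepts all three substituted rings with no clear change in the number. No measurement here explains the gap between these aromatic rings and 2-phenylethenyl.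

The compounds shown leave open whether that gap comes from the double bond or from the longer link to the phenyl ring, a question that a saturated 2-phenylethyl chain at the same carbon would help to settle. It also remains open whether an amine or a carboxylic acid on the aromatic ring would move the number beyond the scatter, in either direction, when the methoxy, chloro and hydroxy groups shown here do not separate from one another.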